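A few compounds are considered here, and "the series" means these few. Any claim that something is new, unique, unknown or untested is made for them only; others in the source may bear on it.

Compound 1 `Cc1ccccc1-n1nncc1CN1C(=O)C2(C(C#N)=C(N)Oc3c(N)cc4nc5ccccc5nc4c32)c2ccccc21` and compound 2 `COc1ccc(OC)c(-n2nncc2CN2C(=O)C3(C(C#N)=C(N)Oc4c(N)cc5nc6ccccc6nc5c43)c3ccccc32)c1` share one core and differ only in the group on an aromatic nitrogen of the five-membered ring. In a functional assay on HCT-116 cells (Homo sapiens) for antiproliferative activity, read by MTT assay, with a stated time of 48 h (on this read-out higher numbers stand for weaker inhibition and lower numbers for stronger inhibition), compound 1 gives > 50000 nM, which is a limit of the assay and not a number. In this assay compound 2 gives > 50000 nM, again a limit rather than a number. The step that the two limits leave unreadable from compound 1 to compound 2 therefore cannot be read, and the limit of > 50000 nM in this assay, at which 2 of the 2 values shown sit, summarises where both values sit. Compound 3 `N#CC1=C(N)Oc2c(N)cc3nc4ccccc4nc3c2C12C(=O)N(Cc1cnnn1-c1ccc(Cl)cc1[N+](=O)[O-])c1ccccc12` carries the change (4-chloro-2-nitrophenyl in place of 2,5-dimethoxyphenyl on an aromatic nitrogen). For the measured compounds named here, only the step from compound 1 to compound 2 bears on it, and that step is hidden by the two limits, so no direction of change can be drawn from it. Compound 3 is expected to behave like its two neighbours, with an estimated step that the limit leaves unreadable from compound 2 to compound 3 from compound 2, which is most likely again unreadable. For compound 3 the estimate in this assay is 60000 nM, with a range from 15000 nM to 250000 nM, and a reported limit rather than a number is the more likely outcome.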

Compound 3, half-maximal inhibitory concentration: 28700 nM
The estimate for compound 3 lay 2.1-fold (0.32 log units) above the measured number; the range from low to high includes it.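

In this assay, for the compounds shown here, compound 3, with 4-chloro-2-nitrophenyl on the aromatic nitrogen of the five-membered ring, gives 28700 nM, the only true number among the three values shown, so a change at this position alone can bring a reading inside the measurable range. Measured against its two neighbours, the result gives an at least 1.7-fold lower number from compound 2 to compound 3 (0.24 log units; that floor lies within the scatter), and also an at least 1.7-fold lower number from compound 1 to compound 3 (0.24 log units; that floor lies within the scatter); these are floors, so the real size of either difference cannot be fixed. The step between compound 1 and compound 2 cannot be read, and both remain at a limit of the assay rather than a number: the limit of > 50000 nM in this assay, at which 2 of the 3 values shown sit.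

The chlorine and the nitro group enter together in compound 3, so the compounds shown cannot tell which of the two, if either, accounts for its measurable value; a phenyl ring carrying only a chlorine or only a nitro group would separate them. Going by these compounds, how an amine, a carboxylic acid or a longer alkyl chain at this position would read in this assay also remains open.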